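The source may hold more compounds than are shown below. What is called first, only, known or untested is meant among the compounds shown, and "the series" means these compounds.

Within the data shown here, in a functional assay on PC-3 cells (Homo sapiens) for antiproliferative activity, read by sulforhodamine B assay (on this read-out lower numbers stand for stronger inhibition of growth and higher numbers for weaker inhibition of growth), the three compounds read so far all end at a limit. Compound 1 (`O=C(/C=C/c1ccc(O)cc1)c1c(O)cccc1OCCC1CCCCC1`) gives > 30000 nM, which is a limit and not a number. Compound 2 (`O=C(/C=C/c1ccc(O)cc1)c1c(O)cccc1OCC1CCCCC1`) gives > 30000 nM, also a limit. Compound 3 (`CCCCOc1cccc(O)c1C(=O)/C=C/c1ccc(O)cc1`) gives > 30000 nM, again a limit. The set therefore has no spread to rank: the limit of > 30000 nM in this assay, at which 3 of the 3 values shown sit.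

Compound 4 (`CC(C)CCOc1cccc(O)c1C(=O)/C=C/c1ccc(O)cc1`) differs from compound 3 by methyl in place of hydrogen on a saturated chain carbon bound to two saturated chain carbons, which reads as butyl to isopentyl.

The bearing steps are all changes to this same chain: a step that the two limits leave unreadable from compound 1 to compound 3, a step that the two limits leave unreadable from compound 2 to compound 3 and a step that the two limits leave unreadable from compound 1 to compound 2. None has a readable size, so none offers a size to carry over, and no step beyond the scatter is expected in this assay, in either direction.

The expected step is a number no higher from compound 3 to compound 4 (the limit leaves the size open). Compound 4 is estimated at 30000 nM, with an expected range of 12000 nM to 60000 nM.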

Compound 4, concentration for 50% growth inhibition: 11500 nM
Compound 4: middle estimate off by 2.6-fold (0.42 log units), on the high side; the measured number lies below the stated range.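

In this assay, among these compounds, butyl to isopentyl gives the first step that can be read, at least as a lower bound: an at least 2.6-fold lower number from compound 3 to compound 4 (0.41 log units; beyond the scatter). The two cycloalkyl-bearing chains give the same kind of reading against the isopentyl chain, an at least 2.6-fold lower number from compound 2 to compound 4 (0.41 log units; beyond the scatter) and an at least 2.6-fold lower number from compound 1 to compound 4 (0.41 log units; beyond the scatter), so at this position a cyclohexyl group at the chain end does not match the reading of the isopentyl chain. The steps among compound 1, compound 2 and compound 3 still cannot be read, as these three compounds end at a limit: the limit of > 30000 nM in this assay, at which 3 of the 4 values shown sit.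

Going by these compounds, the true size of all three new steps stays open, as each starts from a limit. On these data alone, whether a longer chain such as hexyl, or an amine on the chain, would lower the number further also remains open.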